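This account rests on a few compounds, and the source may have more. Where it says the series, first, only, none or still open, it means among the compounds named here.

Compound 1 `O=C1O[C@H]([C@@H](O)Cn2cc(-c3ccc(Br)cc3)nn2)C(OCc2ccccc2)=C1OCc1ccccc1`: 5100 nM
Compound 2 `CC(C)(C)c1cn(C[C@H](O)[C@H]2OC(=O)C(OCc3ccccc3)=C2OCc2ccccc2)nn1`: 13300 nM

Among the measured compounds shown here, in an ADME assay on HFF cells (Homo sapiens) for cytotoxicity, read by MTT assay, with a stated time of 72 h (a lower number here means a stronger inhibitor, a higher number a weaker inhibitor), compound 2 gives 13300 nM, the higher of the two numbers so far, and its nearest neighbour is compound 1 at 5100 nM. Compound 3 `O=C1O[C@H]([C@@H](O)Cn2cc(CCCCl)nn2)C(OCc2ccccc2)=C1OCc1ccccc1` keeps the core of compound 2 and changes one group: 3-chloropropyl in place of tert-butyl on an aromatic carbon. In words, 3-chloropropyl stands in place of tert-butyl on an aromatic carbon, and the same carbon also carries the group that separates compound 1 from compound 2. For the measured compounds named here, only one measured step bears on this change: a 2.6-fold higher number from compound 1 to compound 2 (0.42 log units; beyond the scatter). It is modest but beyond the scatter, and it comes from tert-butyl replacing 4-bromophenyl. Going by the values given here, no measured compound yet carries 3-chloropropyl, so the direction is uncertain. Like tert-butyl, the new group has no ring, so a change smaller than that measured step is expected, leaning slightly toward a lower number and not clearly beyond the scatter. The expected step is a 1.3-fold lower number from compound 2 to compound 3 (0.12 log units; within the scatter). Compound 3 is estimated at 10000 nM, with an expected range from 4500 nM to 22000 nM.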

Compound 3, half-maximal inhibitory concentration: 27100 nM
Compound 3: the middle estimate sits 2.7-fold (0.43 log units) below what was measured; measured number above the stated range.
By their numbers in this assay, from the lowest: compound 1; then compound 2; then compound 3.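

In this assay, the position on an aromatic carbon of the five-membered aromatic ring with 3 nitrogen proves sensitive even when neither group has a ring: tert-butyl and 3-chloropropyl have the same heavy-atom count, yet the change gives a 2.0-fold higher number from compound 2 to compound 3 (0.31 log units; beyond the scatter). The earlier step paired a ringed group with a ringless one, so it could not show this; the full change from the 4-bromophenyl group now spans a 5.3-fold higher number from compound 1 to compound 3 (0.73 log units; beyond the scatter), and among these three compounds the number rises from 4-bromophenyl through tert-butyl to 3-chloropropyl. No measured evidence here explains why the number moves with these groups.

The compounds shown leave open whether the chlorine or the carbon chain accounts for the step from tert-butyl, which a plain propyl chain, a longer chloroalkyl chain or an amine at the end of the chain could help to separate. They also leave open how much of the low number of compound 1 depends on its bromine rather than on the phenyl ring, a question that an unsubstituted phenyl group would address.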